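Changing the Aryl Group on an Inactive Series

This account rests on a few compounds, and the source may have more. Where it says the series, first, only, none or still open, it means among the compounds named here.

Of the compounds shown here, three sharing one core have been measured so far in a functional assay on HepG2 cells (Homo sapiens) for inhibition, read by MTT assay, with a stated time of 48 h; on this read-out lower numbers stand for stronger inhibition and higher numbers for weaker inhibition. Compound 1 `CCSc1nnc(-c2cc(OC)c(OC)c(OC)c2)n1-c1ccc(N(C)C)cc1` gives > 60000 nM, which is a limit of the assay and not a number. Compound 2 `COc1cc(-c2nnc(SCc3ccccc3)n2-c2ccc(N(C)C)cc2)cc(OC)c1OC` gives > 60000 nM, again a limit. Compound 3 `COc1cc(-c2nnc(SCC(=O)c3ccc(F)cc3)n2-c2ccc(N(C)C)cc2)cc(OC)c1OC` gives > 60000 nM, also a limit. Compound 3 therefore stands with the other two, as the limit of > 60000 nM in this assay, at which 3 of the 3 values shown sit, shows.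

Compound 4 `COc1ccc(C(=O)CSc2nnc(-c3cc(OC)c(OC)c(OC)c3)n2-c2ccc(N(C)C)cc2)cc1O` keeps the core and carries 3-hydroxy-4-methoxyphenyl in place of 4-fluorophenyl on a carbonyl carbon.

The measured changes on the saturated chain carbon bound to a sulfur offer no size to carry over. They are a step that the two limits leave unreadable from compound 1 to compound 2, a step that the two limits leave unreadable from compound 1 to compound 3 and a step that the two limits leave unreadable from compound 2 to compound 3. Any readable change in this assay can only run toward stronger inhibition, so a modest shift in that direction is expected, namely an at least 2.4-fold lower number from compound 3 to compound 4 (0.38 log units; beyond the scatter). The estimated value for compound 4 is 25000 nM, with an expected range from 4000 nM to 60000 nM.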

Compound 4, half-maximal inhibitory concentration: > 100000 nM
Compound 4: no number, only a limit; the forecaster's own chance of this, stated with the estimate: 55%; middle value at least 4.0-fold (0.60 log units) from the limit.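

In this assay compound 4 gives > 100000 nM, which is a limit and not a number. For the compounds shown here, compound 1, compound 2 and compound 3 also stand at limits, so no step to compound 4 can be read. The compounds shown leave open whether any group on this carbonyl carbon gives a measurable value.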